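The compounds below may be only part of what the source reports. "The series", "measured", "known", "first", "only" and "open" are said of these compounds alone.

Of the compounds shown here, two have been measured in an assay on cells for inhibition of Voltage-dependent T-type calcium channel subunit alpha-1G (Homo sapiens), read by patch clamp; on this read-out higher numbers stand for weaker inhibition and lower numbers for stronger inhibition. Compound 1 `O=C(CC1c2ccccc2N=C(SCCCCCN2CCCC2)N1c1ccc(-c2ccc(F)cc2)cc1)NCc1ccc(F)cc1` gives 12600 nM in this assay. Compound 2 `CN(C)CCCCCSC1=Nc2ccccc2C(CC(=O)NCc2ccc(F)cc2)N1c1ccccc1` gives 555000 nM in this assay, the higher of the two numbers, and its gap to compound 1 is well beyond the usual scatter. Compound 3 `CN(C)CCCCCSC1=Nc2ccccc2C(CC(=O)NCc2ccc(F)cc2)N1c1ccc(-c2ccc(F)cc2)cc1` is compound 2 with 4-fluorophenyl in place of hydrogen on an aromatic carbon. Among the compounds with values here, no measured pair shows this single change on its own. Because compound 1 also carries this group and gives 12600 nM, a large drop in this assay is expected, a 28-fold lower number from compound 2 to compound 3 (1.44 log units; beyond the scatter). Compound 3 is therefore estimated at 20000 nM, likely between 5000 nM and 80000 nM.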

Compound 3, half-maximal inhibitory concentration: 400 nM
Estimate against measurement, compound 3: 50-fold (1.70 log units) above; measured number below the stated range.
By their numbers in this assay, from the lowest: compound 3; then compound 1; then compound 2.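

In this assay, 4-fluorophenyl in place of hydrogen on an aromatic carbon gives a 1400-fold lower number from compound 2 to compound 3 (3.14 log units; beyond the scatter) as a single change, showing how much this position can matter. The amine end matters as well: with 4-fluorophenyl present, dimethylamino in place of pyrrolidin-1-yl gives a 32-fold lower number from compound 1 to compound 3 (1.50 log units; beyond the scatter) and so outweighs the ring amine. No measurement here offers a reason for either step. From the compounds shown here alone, it remains open whether a chlorine atom or a methoxy group at this position would give a similar drop, and whether a piperidine or a shorter chain would keep it.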